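Isobutyl for isopropoxy on the carbonyl: compound 3

The source may hold more compounds than are shown below. What is called first, only, known or untested is meant among the compounds shown, and "the series" means these compounds.

Within the data shown here, in a functional assay on CHO-K1 cells for agonist activity at Glucose-dependent insulinotropic receptor (Homo sapiens), read by a luciferase reporter, with a stated time of 5 h (a higher number here means that more compound is needed for the effect, a lower number that less compound is needed), compound 1 `CCCS(=O)(=O)N1CCN(c2ccc(OCC3CCN(C(=O)OC(C)C)CC3)cn2)CC1` gives 300 nM, the highest of the two numbers measured so far. In this assay compound 2 `CCCCS(=O)(=O)N1CCN(c2ccc(OCC3CCN(C(=O)OC(C)C)CC3)cn2)CC1` gives 100 nM. Among the measured compounds shown here, the only measured step, a 3.0-fold lower number from compound 1 to compound 2 (0.48 log units; beyond the scatter), concerns the chain on the sulfonyl and leaves the carbonyl end untouched. Compound 3 `CCCS(=O)(=O)N1CCN(c2ccc(OCC3CCN(C(=O)CC(C)C)CC3)cn2)CC1` differs from compound 1 by isobutyl in place of isopropoxy on a carbonyl carbon. For the measured compounds named here, no measured step bears on this change, so the series gives no direction for it. Expected for compound 3 is a step within the scatter, no change at the digits printed from compound 1 to compound 3 (within the scatter). The estimate for compound 3 is 300 nM, with a range from 90 nM to 1000 nM.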

Compound 3, half-maximal effective concentration: 1600 nM
For compound 3 the middle estimate is 5.3-fold (0.73 log units) below the measured one; measured number outside the range, above it.
By their numbers in this assay, from the lowest: compound 2; then compound 1; then compound 3.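

The carbonyl end of the series is not neutral: in this assay, isobutyl in place of isopropoxy on a carbonyl carbon gives a 5.3-fold higher number from compound 1 to compound 3 (0.73 log units; beyond the scatter). The two groups have the same heavy-atom count, and isopropoxy carries an oxygen where isobutyl has only carbon, so the number responds to a change that leaves the size of the group, as counted, untouched. Nothing measured here accounts for the step.

Open, on these data alone, is how an amine or a longer alkoxy chain on this carbonyl would read, and whether the butyl sulfonyl chain of compound 2 would lower the number with isobutyl in place.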